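A few compounds are considered here, and "the series" means these few. Any claim that something is new, unique, unknown or untested is made for them only; others in the source may bear on it.

The measured compounds in a functional assay on WI-38 cells (Homo sapiens) for inhibition; on this read-out lower numbers stand for stronger inhibition and higher numbers for weaker inhibition:
Compound 1 `CCC(C)C(NC(=O)NO)C(=O)NC1CCCCC1` reaches only the limit of the assay, > 100000 nM, and no number.
Compound 2 `O=C1NC(c2ccccc2)C(=O)N1Cc1ccccc1` gives 78900 nM.

In this assay compound 1 thus stands at the limit, as the limit of > 100000 nM in this assay, at which 1 of the 2 values shown sits, shows, and its figure is a limit rather than a measured value. For the measured compounds named here, compound 2 differs from compound 1 in more than one place; its value merely shows a measurable but weak inhibition, so no step between the two is drawn. Compound 3 `CCC(C)C(NC(=O)NO)C(=O)NC1CCCC1` has not yet been measured. It differs from compound 1 by cyclopentyl in place of cyclohexyl on an amide-type nitrogen. Going by the values given here, since compound 1 only reaches the limit > 100000 nM in this assay, no measured step guides the expectation. The step that the limit leaves unreadable from compound 1 to compound 3 is expected to amount to nothing beyond the usual scatter. Compound 3 is therefore estimated at 150000 nM, between 50000 nM and 500000 nM, with a fair chance that only a limit is reported again.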

Compound 3, half-maximal inhibitory concentration: > 100000 nM
Compound 3: a limit, no number; the forecaster's own chance of this, stated with the estimate: 80%; the middle value is on the limit's open side.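

In this assay compound 3 gives > 100000 nM, a limit and no number. With compound 1 also at a limit, no step from compound 1 to compound 3 can be read: the limit of > 100000 nM in this assay, at which 2 of the 3 values shown sit.

The compounds shown leave open whether cyclopentyl in place of cyclohexyl on an amide-type nitrogen changes inhibition at all.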